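Cytotoxicity of two oxadiazole pairs on macrophage cells

The source may hold more compounds than are shown below. What is called first, only, known or untested is meant among the compounds shown, and "the series" means these compounds.

The study compares four compounds on one read-out, an ADME assay on RAW264.7 cells (Mus musculus) for cytotoxicity, read by MTT assay, with a stated time of 48 h; on this read-out lower numbers stand for higher toxicity in this test and higher numbers for lower toxicity in this test. Compound 1 `C#CCN(c1nc(-c2ccc(OC)cc2)no1)C1CCCCC1` gives 28 ug/mL in this assay. Compound 3 `C#CCN(c1nc(-c2ccc(C(F)(F)F)cc2)no1)C1CCCCC1` carries the same core with one change, (trifluoromethyl in place of methoxy on an aromatic carbon), and in this assay compound 3 gives 38.3 ug/mL. The step of a 1.4-fold higher number from compound 1 to compound 3 (0.14 log units; within the scatter) is small. Compound 2 `COc1ccc(-c2noc(N(Cc3cn(C[C@H](CO[C@@H]4C=C[C@H](OC(C)=O)[C@@H](COC(C)=O)O4)OC(C)=O)nn3)C3CCCCC3)n2)cc1` has a far larger structure; the difference between the two cores of compound 1 and compound 2 is not broken down here. In this assay compound 2 gives 86.3 ug/mL, which stands beyond the scatter above both compound 1 and compound 3.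

Compound 4 `CC(=O)OC[C@H]1O[C@H](OC[C@@H](Cn2cc(CN(c3nc(-c4ccc(C(F)(F)F)cc4)no3)C3CCCCC3)nn2)OC(C)=O)C=C[C@@H]1OC(C)=O` is not yet measured. It differs from compound 2 by trifluoromethyl in place of methoxy on an aromatic carbon, the same change that leads from compound 1 to compound 3, at the same place on the ring. For compound 4 in this assay the expected step is a 1.2-fold higher number from compound 2 to compound 4 (0.09 log units; within the scatter), a step that rests on the small shift seen in a 1.4-fold higher number from compound 1 to compound 3 (0.14 log units; within the scatter) and on the value of compound 2, 86.3 ug/mL, as its starting point. Because the earlier step of a 1.4-fold higher number from compound 1 to compound 3 (0.14 log units; within the scatter) lies within the scatter, the expectation for compound 4 is wide, and the number is estimated at 105 ug/mL, between 55 ug/mL and 200 ug/mL.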

Compound 4, half-maximal cytotoxic concentration: 64.1 ug/mL
For compound 4 the middle estimate is 1.6-fold (0.21 log units) above the measured one; measured number inside the range.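

In this assay, trifluoromethyl in place of methoxy on the larger core gives a 1.3-fold lower number from compound 2 to compound 4 (0.13 log units; within the scatter), so on this core too the change stays inside what repeated measurements of this kind can separate. Set beside the step on the smaller core, the change reads alike on both cores, even though the two steps are printed with opposite signs: the same change on two cores in this assay, a 1.4-fold higher number (0.14 log units; within the scatter) from compound 1 to compound 3 and a 1.3-fold lower number (0.13 log units; within the scatter) from compound 2 to compound 4, 1.8-fold (0.27 log units) apart, within the scatter of two such steps. This shows that, for these two pairs, the exchange carried over from one core to the other as a small step, but it gives the change no direction in this test and does not show that the step would remain small on a third core.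

On these data alone, the two pairs cover only the move from 4-methoxyphenyl to 4-(trifluoromethyl)phenyl, so it remains open how a group such as an amine, a carboxylic acid or a nitrile would read at that place on the aromatic ring. Compound 2 and compound 4 also differ from the smaller compounds in more than one place, which leaves open which part of their larger structure goes with their numbers in this assay.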